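Moving two chlorines around a shared core

A few compounds are considered here, and "the series" means these few. Any claim that something is new, unique, unknown or untested is made for them only; others in the source may bear on it.

Three measured compounds share one core and differ only in the aryl group on the double-bonded chain. Compound 1 `O=C(/C=C\c1ccccc1)N1N=C(c2ccncc2)OC1c1c[nH]c2ccccc12` carries a plain phenyl. In an ADME assay on PANC-1 cells (Homo sapiens) for cytotoxicity, read by MTT assay, with a stated time of 48 h (on this read-out lower numbers stand for stronger inhibition of growth and higher numbers for weaker inhibition of growth), compound 1 gives > 30 ug/mL, which is a limit of the assay rather than a number. Compound 2 `O=C(/C=C\c1cccc([N+](=O)[O-])c1)N1N=C(c2ccncc2)OC1c1c[nH]c2ccccc12` has a nitro in place of hydrogen on an aromatic carbon. In this assay compound 2 gives > 30 ug/mL, again only a limit. Compound 3 `O=C(/C=C\c1cccc(Cl)c1Cl)N1N=C(c2ccncc2)OC1c1c[nH]c2ccccc12` carries a 2,3-dichlorophenyl in place of phenyl. In this assay compound 3 gives > 30 ug/mL, also a limit, so compound 3 stands where the other two stand. Because (the limit of > 30 ug/mL in this assay, at which 3 of the 3 values shown sit), the steps a step that the two limits leave unreadable from compound 1 to compound 2, a step that the two limits leave unreadable from compound 1 to compound 3 and a step that the two limits leave unreadable from compound 2 to compound 3 cannot be sized.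

Compound 4 `O=C(/C=C/c1c(Cl)cccc1Cl)N1N=C(c2ccncc2)OC1c1c[nH]c2ccccc12` differs from compound 3 by 2-(2,6-dichlorophenyl)ethenyl in place of 2-(2,3-dichlorophenyl)ethenyl on a carbonyl carbon. Within the data shown here, no measured step shows that changing this aryl group moves the read-out. The step that the limit leaves unreadable from compound 3 to compound 4 is therefore expected to be none beyond the scatter. Compound 4 is expected to give 50 ug/mL in this assay, within 20 ug/mL to 200 ug/mL, most likely again only as a limit.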

Compound 4, concentration for 50% growth inhibition: > 30 ug/mL
Compound 4: no number, only a limit; the forecaster's own chance of this, stated with the estimate: 80%; the middle value does not contradict the limit.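

In this assay compound 4 gives > 30 ug/mL, which is a limit and not a number. No step from compound 1, compound 2 or compound 3 to compound 4 can be sized, because the values share one limit: the limit of > 30 ug/mL in this assay, at which 4 of the 4 values shown sit.

The compounds shown leave open whether any aryl group on the shared core changes growth inhibition in a way that can be read as a number.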